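The source may hold more compounds than are shown below. What is called first, only, known or untested is meant among the compounds shown, and "the series" means these compounds.

Three compounds have so far been measured in an assay on CHO cells with metabotropic glutamate receptor 2 (Homo sapiens) as the target, read by FLIPR; on this read-out higher numbers stand for an effect only at larger amounts of compound and lower numbers for an effect already at smaller amounts:

compound 1 `Cn1c(CN2CCN(c3nc(Cl)ccc3C(F)(F)F)CC2)nc2cc(C(F)(F)F)ccc21` gives 2000 nM;
compound 2 `Cn1c(CN2CCN(c3ccc(Cl)cc3F)CC2)nc2ccccc21` gives 126 nM;
compound 3 `Cn1c(CN2CCC(c3ccccc3C(F)(F)F)CC2)nc2ccccc21` gives 316 nM.

Compound 1 has the highest number of the three, and its gaps to compound 3 and to compound 2 both lie beyond the usual scatter of the measurement, so among these three it is the least potent. The other two compounds differ from compound 1 in several places at once, so neither of them shows what a single change does on its own.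

Compound 4 `Cn1c(CN2CCN(c3nc(Cl)ccc3C(F)(F)F)CC2)nc2cc(F)ccc21` differs from compound 1 in exactly one place: fluoro in place of trifluoromethyl on an aromatic carbon. Everything else in compound 1 stays as it is. Among the compounds with values here, no measured pair shows how this particular exchange moves the number in this assay; compounds 2 and 3 carry no group at all at that place, but they also differ from compound 1 elsewhere, so their lower numbers cannot be traced to that spot alone. The step expected is a 1.7-fold lower number from compound 1 to compound 4 (0.22 log units; within the scatter), a modest move toward a lower number that could still fall within the scatter. Compound 4 is therefore estimated at 1200 nM, within a range from 400 nM to 3500 nM.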

Compound 4, half-maximal effective concentration: 200 nM
Beside the measured number, compound 4's estimate is 6.0-fold (0.78 log units) above it; measured number below the stated range.
By their numbers in this assay, from the lowest: compounds 2, 4 and 3 (each within the scatter of the next, the first and the last beyond it); then compound 1.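

In this assay, putting fluoro in place of trifluoromethyl on this aromatic carbon gives a 10-fold lower number from compound 1 to compound 4 (1.00 log units; beyond the scatter), a step beyond the scatter, while the rest of compound 1 stays unchanged. Within the data shown here, this pair therefore isolates what the earlier compounds could not: this single place can by itself clearly shift the number, and a substantial part of the high number of compound 1 is tied to the group sitting there, with one heavy atom in place of four going along with the lower number. No measurement at hand explains why this exchange has this effect.

From the compounds shown here alone, a single pair gives two points and no trend, so it remains open where a methoxy group, a nitrile or an amine on the same aromatic carbon would fall relative to fluoro and trifluoromethyl. Going by these compounds, it also remains open whether the same exchange would give a step of similar size if the group on the other side of the molecule were different.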